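The source may report more compounds than this note shows. Statements on the series, on what has been measured and on what is new or still open speak of the compounds shown alone.

Compound 1 `COC(=O)c1nc(C)n(-c2ccccc2)n1` gives in a functional assay on Jurkat cells (Homo sapiens) for inhibition, read by MTT assay, with a stated time of 72 h (on this read-out lower numbers stand for stronger inhibition of growth and higher numbers for weaker inhibition of growth), a limit of > 100000 nM, not a number.
Compound 2 `COC(=O)c1nc(C)n(-c2cccc(C(F)(F)F)c2)n1` gives 10600 nM.
Compound 3 `CCc1nc(C(=O)OC)nn1-c1ccc(F)cc1` gives 11000 nM.

Of the three, only compound 2 and compound 3 give numbers, and those two numbers lie within the scatter of each other; compound 1 sits at the limit (the limit of > 100000 nM in this assay, at which 1 of the 3 values shown sits). Compound 4 `COC(=O)c1nc(-c2ccccc2)n(-c2ccc(F)cc2)n1` differs from compound 3 by phenyl in place of ethyl on an aromatic carbon. Among the compounds with values here, the one measured step, an at least 9.4-fold lower number from compound 1 to compound 2 (0.97 log units; beyond the scatter), changes the substituent on the phenyl attached to the ring nitrogen, not the group on the ring carbon, so it does not bear directly on this change. Within the data shown here, with no measured step of the same kind, no step beyond the scatter is expected; the estimated change is a 1.1-fold lower number from compound 3 to compound 4 (0.04 log units; within the scatter). Compound 4 is therefore expected to give about 10000 nM, within a range of 2500 nM to 40000 nM.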

Compound 4, concentration for 50% growth inhibition: 10000 nM
Compound 4: the middle estimate sits on the measured number at the digits printed; the range from low to high includes it.
By their numbers in this assay, from the lowest: compounds 4, 2 and 3 (each within the scatter of the next). At a limit, above all of these: compound 1.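

Phenyl in place of ethyl on this aromatic carbon of the shared core leaves the growth read-out of this assay without a real change (a 1.1-fold lower number from compound 3 to compound 4 (0.04 log units; within the scatter)). This is the only step shown at this ring carbon, since the earlier step concerned the phenyl on the ring nitrogen, and here a six-membered aromatic ring and ethyl give values within the scatter of each other. Nothing at hand explains this outcome. Going by these compounds, whether an amine, a carboxylic acid or a longer chain at this ring carbon would shift the number remains open.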